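The source may report more compounds than this note shows. Statements on the series, on what has been measured and on what is new or still open speak of the compounds shown alone.

Compound 1 `Cn1c(OCC(C)(C)C(=O)Nc2ccccc2)nnc1-c1ccc(NC(=O)c2ccc3ccccc3c2)cc1` was tested in an ADME assay on Caco-2 cells (Homo sapiens) for permeability, in the apical to basolateral direction (on this read-out lower numbers stand for lower permeability and higher numbers for higher permeability), where compound 1 gives 19.8 10^-6 cm/s. Compound 2 `Cc1cc(NC(=O)c2ccc3ccccc3c2)ccc1-c1cnc(OCC(C)(C)C(=O)O)nc1` gives 33 10^-6 cm/s in this assay, and the two numbers lie within the usual scatter of each other, so neither can be called the more permeable. Compound 3 `Cn1c(OCC(C)(C)C(N)=O)nnc1-c1ccc(NC(=O)c2ccc3ccccc3c2)cc1` differs from compound 1 by a single change: hydrogen in place of phenyl on an amide-type nitrogen. For the measured compounds named here, no measured pair shows this change, so the step from compound 1 to compound 3 in this assay is expected to be a modest decrease, a 1.7-fold lower number from compound 1 to compound 3 (0.22 log units; within the scatter), rather than anything large. For compound 3 the estimate is 12 10^-6 cm/s, with a range from 5 10^-6 cm/s to 25 10^-6 cm/s.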

Compound 3, apparent permeability: 0.1 10^-6 cm/s
Compound 3: the middle estimate sits 120-fold (2.08 log units) above what was measured; the whole stated range lies above it.
By their numbers in this assay, from the lowest: compound 3; then compounds 1 and 2 (each within the scatter of the next).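

Putting hydrogen in place of phenyl on the amide-type nitrogen gives a 200-fold lower number from compound 1 to compound 3 (2.30 log units; beyond the scatter) in this assay and so shows that one change at this position can move the read-out far beyond the scatter. Compound 2 could not show this, as it differs from compound 1 in more than one place. No measurement here explains the size of this step.

Still open, from the compounds shown here alone, is where a methyl or benzyl group on this nitrogen would fall relative to compound 1 and compound 3. Going by these compounds, whether the step would be as large on another core also remains open.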